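Cinnamamide series: trifluoromethyl to amino on the styryl ring

This account rests on a few compounds, and the source may have more. Where it says the series, first, only, none or still open, it means among the compounds named here.

Measured so far:
compound 1 `COc1cccc(/C=C/C(=O)Nc2cc(C(=O)c3cc(OC)c(OC)c(OC)c3)ccc2OC)c1` — 1900 nM
compound 2 `COc1ccc(C(=O)c2cc(OC)c(OC)c(OC)c2)cc1NC(=O)/C=C/c1ccc(C(F)(F)F)cc1` — 1600 nM

Both compounds share a core and differ only in the aryl group at the end of the acrylamide chain. In a functional assay on HT-29 cells (Homo sapiens) for cytotoxicity, read by MTT assay, with a stated time of 72 h (on this read-out higher numbers stand for weaker inhibition and lower numbers for stronger inhibition), compound 2 gives the lower of the two numbers, but the gap to compound 1, a 1.2-fold lower number from compound 1 to compound 2 (0.07 log units; within the scatter), lies within the scatter, so the two cannot be ordered.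

Compound 3 `COc1ccc(C(=O)c2cc(OC)c(OC)c(OC)c2)cc1NC(=O)/C=C/c1ccc(N)cc1` carries the change (amino in place of trifluoromethyl on an aromatic carbon). Within the data shown here, no measured step in this set covers an amino group at that place; the only step available, from a methoxy to a trifluoromethyl substituent on the same ring, was too small to separate from the scatter. There is thus no basis for expecting a shift in either direction in this assay, and a step near zero is the working assumption.

Compound 3 is therefore expected to give a number close to that of compound 2, an estimated step of no change at the digits printed from compound 2 to compound 3 (within the scatter), with an estimate of 1600 nM and a range from 500 nM to 5000 nM.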

Compound 3, half-maximal inhibitory concentration: 5600 nM
The estimate for compound 3 lay 3.5-fold (0.54 log units) below the measured number; measured number outside the range, above it.
By their numbers in this assay, from the lowest: compounds 2 and 1 (each within the scatter of the next); then compound 3.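

In this assay, the substituent on this aromatic carbon does matter: amino in place of trifluoromethyl gives a 3.5-fold higher number from compound 2 to compound 3 (0.54 log units; beyond the scatter), and this step lies beyond the scatter, unlike the step between compound 1 and compound 2. The 4-aminophenyl end also separates from the 3-methoxyphenyl end, with a 2.9-fold higher number from compound 1 to compound 3 (0.47 log units; beyond the scatter), so compound 3 carries the highest number of the three, while compound 1 and compound 2 remain unordered. Among these compounds, the series so far offers no measurement that bears on the reason for this shift.

Still open, on these data alone, is whether the shift belongs to the free amino group alone or would also appear with other groups on the same carbon, such as an acetamide, a dimethylamino group, a hydroxyl or a carboxylic acid. Also open, as far as these compounds go, is whether a halogen such as fluorine or chlorine at this place would stay level with trifluoromethyl, which would show how much of the series' range this single carbon controls.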